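Extending the Chain of a Trifluoromethyl-Bearing Analogue

A few compounds are considered here, and "the series" means these few. Any claim that something is new, unique, unknown or untested is made for them only; others in the source may bear on it.

Compound 1 `CCCCCc1cc2ccccc2nc1-c1cc(-c2ccccc2)no1` gives > 100000 nM in a functional assay on COLO 205 cells (Homo sapiens) for inhibition, read by MTT assay, with a stated time of 24 h (a higher number here means a weaker inhibitor, a lower number a stronger inhibitor), which is a limit of the assay and not a number. Compound 2 `CCCCCc1cc2ccccc2nc1-c1cc(-c2ccc(C)cc2)no1` gives > 100000 nM in this assay, again a limit. Compound 3 `CCCCc1cc2ccccc2nc1-c1cc(-c2ccc(C(F)(F)F)cc2)no1` gives 11900 nM in this assay.

Compound 3 is thus the only one of the three with a measured number in this assay; the other two sit at the limit of > 100000 nM in this assay, at which 2 of the 3 values shown sit. Compound 4 `CCCCCc1cc2ccccc2nc1-c1cc(-c2ccc(C(F)(F)F)cc2)no1` differs from compound 3 by methyl in place of hydrogen on a saturated chain carbon, four bonds along the chain from an aromatic carbon. Within the data shown here, the only measured step, a step that the two limits leave unreadable from compound 1 to compound 2, concerns the aromatic ring and its size is unreadable; no measured step touches the chain. No step beyond the scatter is therefore expected from compound 3 to compound 4, a 1.0-fold higher number from compound 3 to compound 4 (0.00 log units; within the scatter). Compound 4 is estimated at 12000 nM, within 4000 nM to 40000 nM.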

Compound 4, half-maximal inhibitory concentration: 24500 nM
Compound 4: the middle estimate sits 2.0-fold (0.31 log units) below what was measured; the measured number falls inside the stated range.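

Among these compounds, this position on the chain, which no earlier step touched, is not silent: in this assay the change gives a 2.1-fold higher number from compound 3 to compound 4 (0.31 log units; beyond the scatter). Among the compounds shown here, with the chain held the same, trifluoromethyl on the aromatic carbon gives the first readable steps at that place, an at least 4.0-fold lower number from compound 2 to compound 4 (0.61 log units; beyond the scatter) and an at least 4.0-fold lower number from compound 1 to compound 4 (0.61 log units; beyond the scatter). Both are bounds and not exact sizes, as one end of each is a limit of the assay: the limit of > 100000 nM in this assay, at which 2 of the 4 values shown sit.

As far as these compounds go, whether a longer chain at this position moves the number further remains open. So does whether a carboxylic acid or an amine on the aromatic carbon would compare with trifluoromethyl.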